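The compounds below may be only part of what the source reports. "The series", "measured", "known", "first", "only" and "open" are said of these compounds alone.

Compound 1, `O=C(CCCCCCc1ccccc1)c1nc(Br)co1` — in an assay on HEK-293T cells for inhibition of diacylglycerol lipase-alpha (Homo sapiens), read by colorimetric assay (a lower number here means a stronger inhibitor, a higher number a weaker inhibitor), compound 1 gives > 10000 nM, a limit of the assay.
Compound 2, `CS(=O)(=O)c1cnc(C(=O)CCCCCCc2ccccc2)o1` — in this assay compound 2 gives > 10000 nM, also a limit of the assay.

Compound 2 therefore stands at the limit of > 10000 nM in this assay, at which 2 of the 2 values shown sit, and no number below that limit is known for it. Compound 3, `O=C(CCCCCCc1ccccc1)c1ncc(-c2ccccc2F)o1`, is its untested relative: the change is 2-fluorophenyl in place of methylsulfonyl on an aromatic carbon. With no measured step among the two compounds, any expectation for compound 3 rests only on the two limits shown. Both compound 1 and compound 2 sit at the limit, and the two limits give no hint of which way a different group on that carbon would move the value. Compound 3 is therefore expected to remain near the limit, with the step of an at least 1.4-fold lower number from compound 2 to compound 3 (0.15 log units; that floor lies within the scatter) estimated as no more than a modest gain in this assay, and compound 3 is estimated at 7000 nM, between 500 nM and 30000 nM.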

Compound 3, half-maximal inhibitory concentration: > 10000 nM
Compound 3 ended at the assay's limit; the forecaster's own chance of this, stated with the estimate: 60%; middle value at least 1.4-fold (0.15 log units) from the limit.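

No step can be read from compound 2 to compound 3, because neither gives a number, only a limit: the limit of > 10000 nM in this assay, at which 3 of the 3 values shown sit. The compounds shown leave open whether any group on that aromatic carbon would give a value inside the range of this assay.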